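The source may hold more compounds than are shown below. What is called first, only, known or untested is meant among the compounds shown, and "the series" means these compounds.

Measured compounds in an ADME assay on microsomes from liver (Homo sapiens) for metabolic stability, read by LC-MS, using NADPH, with a stated time of 10 min, tested at 0.1 uM; on this read-out lower numbers stand for slow clearance and higher numbers for fast clearance:
compound 1 `CC1SC(c2cccc(C(=O)NCCCCc3ccccc3)c2)N(c2ccc(C3CC3)cc2)C1=O` gives 2010 mL.min-1.g-1
compound 2 `O=C(NCCCCc1ccccc1)c1cccc(C2SCC(=O)N2c2ccccn2)c1` gives 412 mL.min-1.g-1
compound 3 `CC(F)(F)c1cccc(N2C(=O)CSC2c2cccc(C(=O)NCCCCc3ccccc3)c2)c1` gives 1750 mL.min-1.g-1

Among the three numbers, compound 3 stands second highest; its value lies within the scatter of compound 1, while compound 2 sits well below it, separated by a 4.2-fold higher number from compound 2 to compound 3 (0.63 log units; beyond the scatter).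

Compound 4 `O=C(NCCCCc1ccccc1)c1cccc(C2SCC(=O)N2c2ccc(C3CC3)cc2)c1` has not yet been measured in this assay. It differs from compound 3 by a group of 9 heavy atoms (9 carbon; one three-membered non-aromatic ring of carbon only, one six-membered aromatic ring of carbon only) in place of a group of 10 heavy atoms (8 carbon, 2 fluorine; one six-membered aromatic ring of carbon only), on an amide-type nitrogen in a ring. Within the data shown here, the only measured step that touches the same position is the one from compound 2 to compound 3, a 4.2-fold higher number from compound 2 to compound 3 (0.63 log units; beyond the scatter), and it swaps a ring with one hetero atom for a ring of carbon only; the change to compound 4 instead exchanges one carbon-only aromatic ring for another. Compound 1 carries the same 4-cyclopropylphenyl group on its ring nitrogen and gives a number close to that of compound 3, which offers some support for expecting little movement here. Compound 4 is therefore expected to stay near compound 3, with a step of a 1.1-fold higher number from compound 3 to compound 4 (0.04 log units; within the scatter) that should lie within the scatter. The estimate for compound 4 is 1900 mL.min-1.g-1, with a range from 950 mL.min-1.g-1 to 3800 mL.min-1.g-1.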

Compound 4, intrinsic clearance in microsomes in the Homo sapiens assay: 811 mL.min-1.g-1
Estimate against measurement, compound 4: 2.3-fold (0.37 log units) above, and the stated range ends above it.
By their numbers in the Homo sapiens assay, from the lowest: compounds 2 and 4 (each within the scatter of the next); then compounds 3 and 1 (each within the scatter of the next).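

In the Homo sapiens assay the exchange on the amide-type nitrogen in a ring is not neutral between carbon-only aromatic groups: it gives a 2.2-fold lower number from compound 3 to compound 4 (0.33 log units; beyond the scatter) and so separates the two compounds, whereas the change from pyridin-2-yl gives a 2.0-fold higher number from compound 2 to compound 4 (0.29 log units; within the scatter) and leaves that pair no further apart than the usual scatter. With the 4-cyclopropylphenyl group held constant, hydrogen in place of methyl on a saturated ring carbon gives a 2.5-fold lower number from compound 1 to compound 4 (0.39 log units; beyond the scatter) and so the number for compound 1 does not speak for the 4-cyclopropylphenyl group alone. Among these compounds, the step in clearance finds no counterpart in a physicochemical assay for solubility, read by turbidimetry, measured as kinetic solubility, at pH 7.4 (a lower number here means a less soluble compound, a higher number a more soluble compound), where compound 3 gives 2000 nM and compound 4 gives 2000 nM in a comparison showing no change at the digits printed from compound 3 to compound 4 (within the scatter) for this exchange.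

It remains open whether the methyl on the saturated ring carbon would move the number by a similar step with pyridin-2-yl on the amide-type nitrogen, and where a plain phenyl or a 4-methoxyphenyl group would fall among these compounds. No measurement at hand gives a reason for the steps seen here.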